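A few compounds are considered here, and "the series" means these few. Any claim that something is new, unique, unknown or untested is made for them only; others in the source may bear on it.

In an ADME assay (liver) for metabolic stability, with Liver microsome (Rattus norvegicus) as the target, using microsomes (on this read-out higher numbers stand for fast clearance and lower numbers for slow clearance), compound 1 (`c1ccc(CNc2nnc(-c3nc4ccncc4s3)o2)cc1`) gives 66 mL.min-1.g-1 and compound 2 (`O=c1[nH]c2ccc(-c3nnc(NCc4ccccc4)o3)cc2o1`) gives 30 mL.min-1.g-1 on the same scale. Compound 3 (`c1ccc(CNc2nnc(-c3c[nH]c4ncccc34)o2)cc1`) gives 40 mL.min-1.g-1 there, a number within the usual scatter of repeat measurements from each of the other two, so it cannot be told apart from either of them.

The next compound, compound 4 (`Fc1ccccc1CNc1nnc(-c2c[nH]c3ncccc23)o1`), differs from compound 3 in one place: fluoro in place of hydrogen on an aromatic carbon with fluoro in place of hydrogen on an aromatic carbon, which turns phenyl to 2-fluorophenyl. Going by the values given here, no two measured compounds here differ in only one place, so the data show nothing directly about this swap. With so little evidence, no step beyond the scatter is expected in this assay in either direction. The expected change, a 1.1-fold higher number from compound 3 to compound 4 (0.02 log units; within the scatter) and stays within that scatter. For compound 4 the estimated value is 42 mL.min-1.g-1 with an expected range from 22 mL.min-1.g-1 to 80 mL.min-1.g-1 on this read-out.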

Compound 4, intrinsic clearance in microsomes: 46 mL.min-1.g-1
For compound 4 the middle estimate is 1.1-fold (0.04 log units) below the measured one; the measured number falls inside the stated range.
By their numbers in this assay, from the lowest: compounds 2, 3, 4 and 1 (each within the scatter of the next, the first and the last beyond it).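

Fluoro in place of hydrogen on an aromatic carbon, ortho to a large group, gives the first direct reading at this position, and in this assay it amounts to a 1.2-fold higher number from compound 3 to compound 4 (0.06 log units; within the scatter) on the shared core. For this single pair, then, turning phenyl to 2-fluorophenyl leaves microsomal clearance indistinguishable from that of the unsubstituted compound. Nothing measured here explains this result.

Still open, going by these compounds, is whether a larger group at the same place, such as chloro, methoxy or trifluoromethyl, would move the number beyond the scatter. Also open, on these data alone, is whether the same fluoro swap would behave alike on the cores of compound 1 and compound 2.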